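The source may hold more compounds than are shown below. What is called first, only, known or untested is meant among the compounds shown, and "the series" means these compounds.

Compounds measured so far:
- compound 1, `O=C(OC1(C(=O)Nc2ccc([N+](=O)[O-])cc2)CCCCC1)c1ccccc1I`: 619 nM
- compound 2, `O=C(/C=C/c1ccccc1)OC1(C(=O)Nc2ccc([N+](=O)[O-])cc2)CCCCC1`: 57.6 nM
- compound 3, `O=C(OC1(C(=O)Nc2ccc([N+](=O)[O-])cc2)CCCCC1)c1ccccc1`: 903 nM

All three values come from a functional assay on MCF7 cells (Homo sapiens) for inhibition, read by MTT assay, with a stated time of 72 h; on this read-out lower numbers stand for stronger inhibition and higher numbers for weaker inhibition. Compound 3 gives the highest number of the three; its nearest neighbour is compound 1, and the two lie within the scatter of each other, the only difference being hydrogen in place of iodo on the aromatic carbon of the ester-bearing ring (a 1.5-fold higher number from compound 1 to compound 3 (0.16 log units; within the scatter)). Compound 2, with the 2-phenylethenyl ester, stands well apart: a 16-fold higher number from compound 2 to compound 3 (1.20 log units; beyond the scatter) and an 11-fold lower number from compound 1 to compound 2 (1.03 log units; beyond the scatter) are both large and beyond the scatter, but they concern a different change and do not bear on the present step.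

Compound 4, `CC(=O)Oc1ccccc1C(=O)OC1(C(=O)Nc2ccc([N+](=O)[O-])cc2)CCCCC1`, is not yet measured in this assay. It differs from compound 3 by acetoxy in place of hydrogen on an aromatic carbon. Going by the values given here, the one measured step that touches the same place is the iodo-to-hydrogen step, which stayed within the scatter. Among the compounds with values here, the acetoxy group is larger than iodo and carries two hydrogen-bond acceptors, so the carry-over is uncertain, but there is no measured precedent for a large effect from a substituent at this position.

Compound 4 is therefore expected to sit close to compound 3, with a step of a 1.3-fold lower number from compound 3 to compound 4 (0.11 log units; within the scatter) that is not clearly beyond the scatter; the estimate for compound 4 in this assay is 700 nM, range 250 nM to 2000 nM.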

Compound 4, half-maximal inhibitory concentration: 16.9 nM
Compound 4: middle estimate off by 41-fold (1.62 log units), on the high side; the whole stated range lies above it.
By their numbers in this assay, from the lowest: compound 4; then compound 2; then compounds 1 and 3 (each within the scatter of the next).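

In this assay, the aromatic carbon ortho to a large group proves sensitive to what stands on it: acetoxy in place of hydrogen gives a 53-fold lower number from compound 3 to compound 4 (1.73 log units; beyond the scatter) and so opens a far larger gap than the earlier iodo comparison, which gave only a 1.5-fold higher number from compound 1 to compound 3 (0.16 log units; within the scatter) and stayed within the scatter. The change depends on the entering group and not merely on the place being filled, as acetoxy in place of iodo gives a 37-fold lower number from compound 1 to compound 4 (1.56 log units; beyond the scatter) at the same carbon. The substituted benzoate series also no longer trails the 2-phenylethenyl ester, since 2-acetoxyphenyl in place of 2-phenylethenyl gives a 3.4-fold lower number from compound 2 to compound 4 (0.53 log units; beyond the scatter) and compound 4 has the lowest number of the four, with its steps to all three others beyond the scatter.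

Still open, from the compounds shown here alone, is whether the whole acetoxy group is required, which a hydroxyl, methoxy or longer propanoyloxy group on the same carbon would help to settle. The compounds shown offer no measurement that accounts for the drop in number.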